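Changing one substituent on a shared core

The source may hold more compounds than are shown below. What is called first, only, known or untested is meant among the compounds shown, and "the series" means these compounds.

Three compounds share one core and differ at a single place. Compound 1 `CC(=O)N1CCN(c2ccc(Nc3ncc(C(F)(F)F)c(N4Cc5cccc(N(C)S(C)(=O)=O)c5C4)n3)cc2)CC1` carries 4-acetylpiperazin-1-yl there, and in an assay on Sf9 cells for inhibition of tyrosine-protein kinase receptor UFO (Homo sapiens), read by luminescence and ADP-Glo (on this read-out higher numbers stand for weaker inhibition and lower numbers for stronger inhibition), compound 1 gives < 0.5 nM, which is a limit of the assay rather than a number. Compound 2 `CN(c1cccc2c1CN(c1nc(Nc3ccc(Nc4ccccc4)cc3)ncc1C(F)(F)F)C2)S(C)(=O)=O` carries anilino instead, and in this assay compound 2 gives > 20000 nM, again a limit and not a number. Compound 3 `CN(c1cccc2c1CN(c1nc(Nc3ccc(C(F)(F)F)cc3)ncc1C(F)(F)F)C2)S(C)(=O)=O` carries trifluoromethyl, and in this assay compound 3 gives > 20000 nM, also a limit. The steps of an at least 40000-fold higher number from compound 1 to compound 2 (4.60 log units; beyond the scatter) and an at least 40000-fold higher number from compound 1 to compound 3 (4.60 log units; beyond the scatter) show that both replacements lose a great deal of inhibition, while the step that the two limits leave unreadable from compound 2 to compound 3 cannot be read, as both ends sit at the limit of > 20000 nM in this assay, at which 2 of the 3 values shown sit. Compound 4 `CN(c1cccc2c1CN(c1nc(Nc3ccc(Cl)c(C(F)(F)F)c3)ncc1C(F)(F)F)C2)S(C)(=O)=O` is not yet measured; it differs from compound 3 by 4-chloro-3-(trifluoromethyl)phenyl in place of 4-(trifluoromethyl)phenyl on a nitrogen on an aromatic ring. Compound 3 already sits at the limit of > 20000 nM in this assay, at which 2 of the 3 values shown sit, and adding one chlorine to that ring is expected to leave the step that the limit leaves unreadable from compound 3 to compound 4 within the scatter. Compound 4 is therefore expected to give about 25000 nM, between 4000 nM and 100000 nM.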

Compound 4, half-maximal inhibitory concentration: > 20000 nM
Compound 4: no number, only a limit (the forecaster's own chance of this, stated with the estimate: 70%); the middle value is on the limit's open side.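

Among these compounds, compound 3 and compound 4 both give only a limit in this assay, not a number, so no step between them can be read: the limit of > 20000 nM in this assay, at which 3 of the 4 values shown sit. As far as these compounds go, how strongly either compound inhibits, and whether 4-chloro-3-(trifluoromethyl)phenyl in place of 4-(trifluoromethyl)phenyl changes that inhibition at all, stays open.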